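This account rests on a few compounds, and the source may have more. Where it says the series, first, only, none or still open, it means among the compounds named here.

Measured compounds:
compound 1 `COC(=O)c1cccc(-c2nnc(C(=O)CCCCCCc3ccccc3)o2)n1` — in an assay for inhibition of Fatty-acid amide hydrolase 1 (Rattus norvegicus) (a lower number here means a stronger inhibitor, a higher number a weaker inhibitor), compound 1 gives 8 nM
compound 2 `O=C(CCCCCCc1ccccc1)c1ncno1` — in this assay compound 2 gives 4 nM
compound 3 `COC(=O)c1cccc(-c2noc(C(=O)CCCCCCc3ccccc3)n2)n1` — in this assay compound 3 gives 3 nM

Compound 2 sits between the other two numbers: compound 3 lies a little lower and compound 1 a little higher, and both of those gaps are within the usual scatter of this assay, so the three compounds cannot be separated on these numbers.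

Compound 4 `O=C(CCCCCCc1ccccc1)c1ncon1` has not yet been measured. It is built from the same atoms as compound 2, joined differently: 1,2,4-oxadiazol-3-yl in place of 1,2,4-oxadiazol-5-yl on a carbonyl carbon. Among the measured compounds shown here, no measured pair in this set isolates that change, so the size of its effect is unknown. All three measured compounds carry a five-membered ring with three hetero atoms on the carbonyl carbon and land within the scatter of one another, which gives no reason to expect a step beyond the scatter in either direction; at most a mild weakening is allowed for. Compound 4 is therefore estimated at 8 nM, with a range from 2 nM to 30 nM, which would mean a step of a 2.0-fold higher number from compound 2 to compound 4 (0.30 log units; within the scatter) that is expected to stay small.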

Compound 4, half-maximal inhibitory concentration: 500 nM
The estimate for compound 4 lay 63-fold (1.80 log units) below the measured number; measured number outside the range, above it.
By their numbers in this assay, from the lowest: compounds 3, 2 and 1 (each within the scatter of the next, the first and the last beyond it); then compound 4.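

In this assay, among the compounds shown here, 1,2,4-oxadiazol-3-yl in place of 1,2,4-oxadiazol-5-yl on a carbonyl carbon brings a 130-fold higher number from compound 2 to compound 4 (2.10 log units; beyond the scatter), so this position responds strongly to how the group is joined, which the earlier compounds could not show. The two groups match in every count computed, with the same heavy atoms, hydrogen-bond acceptors and charge, so those counts do not predict the outcome here, and a similar group on the carbonyl carbon cannot be assumed to behave alike. Nothing available here accounts for the size of this step.

The compounds shown leave open whether 1,2,4-oxadiazol-3-yl would weaken inhibition to the same extent if it carried the methyl ester-bearing substituent found in compound 3. They also leave open how a carboxylic acid in place of that methyl ester, or a longer chain on the carbonyl carbon, would behave with either group.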